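Bile acid receptor series: aryl swap on the carbamoyl core

A few compounds are considered here, and "the series" means these few. Any claim that something is new, unique, unknown or untested is made for them only; others in the source may bear on it.

Measured compounds:
- compound 1, `COC(=O)/C=C/c1cccc(N(Cc2ccc(/C=C/c3cccc(F)c3)cc2)C(=O)C2CCCCC2)c1`: 86 nM
- compound 2, `COC(=O)/C=C/c1cccc(N(Cc2ccc(-c3cccc(Cl)c3)cc2)C(=O)C2CCCCC2)c1`: 94 nM
- compound 3, `COC(=O)/C=C/c1cccc(N(Cc2ccc(/C=C/c3cccc(F)c3)cc2)C(=O)NC(C)C)c1`: 467 nM

Three compounds have been run in an assay on isolated protein with Bile acid receptor (Homo sapiens) as the target; on this read-out higher numbers stand for an effect only at larger amounts of compound and lower numbers for an effect already at smaller amounts. Compound 1 gives 86 nM and compound 2 gives 94 nM; the change between them is 3-chlorophenyl in place of 2-(3-fluorophenyl)ethenyl on an aromatic carbon and the step is a 1.1-fold higher number from compound 1 to compound 2 (0.04 log units; within the scatter), so the two are not separated here. Compound 3 gives 467 nM; it differs from compound 1 in its core, (isopropylamino in place of cyclohexyl on a carbonyl carbon), and the step is a 5.4-fold higher number from compound 1 to compound 3 (0.73 log units; beyond the scatter). Compound 3 stands at the highest number of the three, beyond the scatter from both others.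

Compound 4, `COC(=O)/C=C/c1cccc(N(Cc2ccc(-c3cccc(Cl)c3)cc2)C(=O)NC(C)C)c1`, has not been measured. It relates to compound 3 as compound 2 relates to compound 1: the change is 3-chlorophenyl in place of 2-(3-fluorophenyl)ethenyl on an aromatic carbon, at the same place, so it is the same change carried onto the core of compound 3. For the measured compounds named here, the only measured example of that change, a 1.1-fold higher number from compound 1 to compound 2 (0.04 log units; within the scatter), lies within the scatter, so the expectation for this assay is that compound 4 stays near compound 3, with the step estimated as a 1.1-fold higher number from compound 3 to compound 4 (0.03 log units; within the scatter). Going by the values given here, on that basis compound 4 is expected to give about 500 nM in this assay, with a range estimated from 200 nM to 1300 nM; the single prior example of the change gives the only support for this, so the range is kept wide.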

Compound 4, half-maximal effective concentration: 1400 nM
Estimate against measurement, compound 4: 2.8-fold (0.45 log units) below; the measured number lies above the stated range.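

In this assay, 3-chlorophenyl in place of 2-(3-fluorophenyl)ethenyl with isopropylamino on the carbonyl carbon gives a 3.0-fold higher number from compound 3 to compound 4 (0.48 log units; beyond the scatter), so the change does not carry over unchanged from the cyclohexyl pair: the same change on two cores in this assay, a 1.1-fold higher number (0.04 log units; within the scatter) from compound 1 to compound 2 and a 3.0-fold higher number (0.48 log units; beyond the scatter) from compound 3 to compound 4, 2.7-fold (0.44 log units) apart, beyond the scatter of two such steps

Read the other way, isopropylamino in place of cyclohexyl gives a 15-fold higher number from compound 2 to compound 4 (1.17 log units; beyond the scatter) when 3-chlorophenyl is present, so the two changes do not add up independently in these four compounds: the same change on two cores in this assay, a 5.4-fold higher number (0.73 log units; beyond the scatter) from compound 1 to compound 3 and a 15-fold higher number (1.17 log units; beyond the scatter) from compound 2 to compound 4, 2.7-fold (0.44 log units) apart, beyond the scatter of two such steps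

This shows that the size of each step depends on the group at the other place, but it rests on a single set of four compounds, so it gives neither a rule for other cores nor a reason for the dependence.

The compounds shown leave open whether the gap belongs to isopropylamino specifically or would also appear with another group on the carbonyl carbon, such as a cyclopentyl group or a longer alkylamino chain, and whether other aryl groups would behave like 3-chlorophenyl. They also leave open whether the same dependence holds with a carboxylic acid in place of the methyl ester.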